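A few compounds are considered here, and "the series" means these few. Any claim that something is new, unique, unknown or untested is made for them only; others in the source may bear on it.

Compound 1 `O=C(CCl)Nc1cccc(-c2nc3ccccc3s2)c1`, compound 2 `COc1ccc(-c2nc3ccccc3s2)cc1NC(=O)c1cnccc1Cl` and compound 3 `Cc1ccc(-c2nc3ccccc3o2)cc1NC(=O)c1cnccc1Cl` have all been tested in a physicochemical assay for solubility, in phosphate buffer, measured as kinetic solubility, with a stated time of 18 h, at pH 7.4; on this read-out lower numbers stand for lower solubility and higher numbers for higher solubility. In this assay compound 1 gives 1000 nM, compound 2 gives 340 nM and compound 3 gives 510 nM. The number for compound 3 is separated from that of compound 2 and from that of compound 1 by less than the usual scatter of repeated measurements of this kind, so on the numbers shown the three compounds cannot be told apart in this assay.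

Compound 4 `COc1ccc(-c2nc3ccccc3o2)cc1NC(=O)c1cnccc1Cl` has not yet been measured in this assay. It differs from compound 3 in one place: methoxy in place of methyl on an aromatic carbon. Compound 2 carries the same methoxy group with a different shared core and gives 340 nM, which stands close to what compound 3 gives with methyl; this gives no reason to expect that the change from methyl to methoxy moves the number beyond the scatter. The step from compound 3 to compound 4 is therefore expected to be small, a 1.3-fold lower number from compound 3 to compound 4 (0.11 log units; within the scatter), and in no clear direction. For compound 4 in this assay the estimate is 400 nM, expected to fall between 150 nM and 1100 nM.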

Compound 4, solubility: 1680 nM
For compound 4 the middle estimate is 4.2-fold (0.62 log units) below the measured one; measured number outside the range, above it.
By their numbers in this assay, from the lowest: compounds 2, 3, 1 and 4 (each within the scatter of the next, the first and the last beyond it).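

Within the data shown here, on the shared core, methoxy in place of methyl on this aromatic carbon, ortho to a large group and para to a group of 9 heavy atoms, gives a 3.3-fold higher number from compound 3 to compound 4 (0.52 log units; beyond the scatter) in this assay, so this position does respond to the change by more than the scatter, something no one-place pair among the earlier compounds could show. With the methoxy group held fixed, 1,3-benzoxazol-2-yl in place of 1,3-benzothiazol-2-yl on an aromatic carbon gives a 4.9-fold higher number from compound 2 to compound 4 (0.69 log units; beyond the scatter), a second one-place reading that also lies beyond the scatter. Nothing available here accounts for either step.

The compounds shown include no pair that repeats the methoxy-for-methyl change with 1,3-benzothiazol-2-yl in place, so whether the step carries over to that setting stays open. Also open, as far as these compounds go, is how this assay would read with an amine or an ethoxy group at this same position, and so whether the step belongs to methoxy alone or extends to other groups there.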